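This account rests on a few compounds, and the source may have more. Where it says the series, first, only, none or still open, it means among the compounds named here.

Measured so far:
- compound 1, `N#Cc1cnc(NCc2cnccc2C(F)(F)F)cc1N[C@H]1CC[C@@H](O)CC1`: 33%
- compound 2, `N#Cc1cnc(NCc2ccccc2C(F)(F)F)cc1N[C@H]1CC[C@@H](O)CC1`: 0%

In an ADME assay on S9 fraction from liver (Homo sapiens) for metabolic stability, with a stated time of 1 h (a higher number here means that more of the compound is left, a lower number that less of the compound is left), compound 1 gives 33%, the higher of the two numbers; compound 2 gives 0%, a gap that lies beyond the scatter. Compound 3, `CNC(=O)[C@H]1CC[C@@H](Nc2cc(NCc3cnccc3C(F)(F)F)ncc2C#N)CC1`, has not been measured. It differs from compound 1 in one place: methylcarbamoyl in place of hydroxy on a saturated ring carbon. Going by the values given here, no measured pair shows this change, so the expectation rests on compound 1 alone. A modest rise, or no change beyond the scatter, is expected as a number 12 percentage points higher from compound 1 to compound 3 (beyond the scatter). Compound 3 is thus estimated at 45%, within 20% to 75%.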

Compound 3, percent of the compound remaining: 71%
Compound 3: middle estimate off by 26 percentage points, on the low side, within the range that was stated.
By their numbers in this assay, from the lowest: compound 2; then compound 1; then compound 3.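

In this assay, exchanging 4-hydroxycyclohexyl for 4-(methylcarbamoyl)cyclohexyl gives a number 38 percentage points higher from compound 1 to compound 3 (beyond the scatter) and so counts as a large step. The earlier compounds shown here both carry the hydroxy group, so only this result shows that the group on this saturated ring carbon can strongly change how much compound remains. Nothing available explains why the number rises.

From the compounds shown here alone, it remains open whether an amine, a carboxylic acid or a longer chain on this ring carbon would give a similar rise. Going by these compounds, it is also open whether methylcarbamoyl would raise the number on the core of compound 2.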